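Swapping a methyl for a nitro on the pendant phenyl

The source may report more compounds than this note shows. Statements on the series, on what has been measured and on what is new or still open speak of the compounds shown alone.

Measured so far:
- compound 1, `O=c1c2ccccc2[se]n1-c1nnc(-c2ccc(F)cc2)s1`: 42900 nM
- compound 2, `Cc1ccccc1-c1nnc(-n2[se]c3ccccc3c2=O)s1`: 19400 nM
- compound 3, `Cc1cccc(-c2nnc(-n3[se]c4ccccc4c3=O)s2)c1`: 17800 nM

All three compounds share the same core and differ only in the substituted phenyl ring attached to it. They were tested in a functional assay on SSMC-7721 cells (Homo sapiens) for antiproliferative activity, read by CCK-8 assay, with a stated time of 48 h; a higher number here means a weaker inhibitor, a lower number a stronger inhibitor. Compound 2 sits second highest of the three numbers; the step of a 2.2-fold lower number from compound 1 to compound 2 (0.34 log units; beyond the scatter) separates it from compound 1, whereas the step of a 1.1-fold lower number from compound 2 to compound 3 (0.04 log units; within the scatter) to compound 3 is too small to count as a real difference.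

The next compound, compound 4, has the structure `O=c1c2ccccc2[se]n1-c1nnc(-c2ccccc2[N+](=O)[O-])s1`. Relative to compound 2 the change is nitro in place of methyl on an aromatic carbon.

Which measured steps bear on this? Only loosely: a 2.2-fold lower number from compound 1 to compound 2 (0.34 log units; beyond the scatter) and a 2.4-fold lower number from compound 1 to compound 3 (0.38 log units; beyond the scatter) show that changing the single substituent on this phenyl ring moved the number modestly, while a 1.1-fold lower number from compound 2 to compound 3 (0.04 log units; within the scatter) shows that moving the methyl around the ring did almost nothing. Going by the values given here, no measured step involves a nitro group, so there is no direct precedent. Given that every change so far has been modest or within the scatter, the step is expected to be small in this assay, with no confident direction; the expected step is a 1.1-fold higher number from compound 2 to compound 4 (0.05 log units; within the scatter). Compound 4 is therefore estimated at 22000 nM, within a range from 7000 nM to 65000 nM.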

Compound 4, half-maximal inhibitory concentration: 22500 nM
Compound 4: the middle estimate sits 1.0-fold (0.01 log units) below what was measured; low and high end bracket the measured number.
By their numbers in this assay, from the lowest: compounds 3, 2, 4 and 1 (each within the scatter of the next, the first and the last beyond it).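

In this assay, putting nitro in place of methyl on an aromatic carbon, ortho to a large group, gives a 1.2-fold higher number from compound 2 to compound 4 (0.06 log units; within the scatter), so the two compounds cannot be told apart. Going by these compounds alone, until now, the only change that stayed within the scatter was moving a methyl around the phenyl ring, with the group itself unchanged. This step shows that a different group can take this place without a readable change in the number, even though nitro brings 3 heavy atoms and 2 hydrogen-bond acceptors where methyl has 1 heavy atom and 0 hydrogen-bond acceptors. Nothing given here explains this result or reports a measured property of either group.

The compounds shown leave open whether this tolerance extends to an amine, a carboxylic acid or a longer chain such as propyl at the same place on the phenyl ring. Also open is how nitro would read at other places on that ring, and whether the same result would hold outside this assay, since the compounds shown carry nitro at this one place and are read in this one assay.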